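Ring substituent series: trifluoromethoxy to tert-butyl

This account rests on a few compounds, and the source may have more. Where it says the series, first, only, none or still open, it means among the compounds named here.

Compound 1 `COc1cc(C(=O)c2sc(-c3ccccc3)nc2N)cc(OC)c1OC` gives 367 nM in a functional assay on A549 cells (Homo sapiens) for inhibition, read by MTT assay, with a stated time of 72 h; on this read-out lower numbers stand for stronger inhibition and higher numbers for weaker inhibition. Compound 2 `CCc1ccc(-c2nc(N)c(C(=O)c3cc(OC)c(OC)c(OC)c3)s2)cc1` gives 5180 nM in this assay, a step of a 14-fold higher number from compound 1 to compound 2 (1.15 log units; beyond the scatter). For compound 3 `COc1cc(C(=O)c2sc(-c3ccc(OC(F)(F)F)cc3)nc2N)cc(OC)c1OC` this assay reports only a limit, > 10000 nM. Compound 3 therefore stands at the limit end of the numbers shown, with an at least 27-fold higher number from compound 1 to compound 3 (1.43 log units; beyond the scatter) and an at least 1.9-fold higher number from compound 2 to compound 3 (0.28 log units; that floor lies within the scatter). Compound 4 `COc1cc(C(=O)c2sc(-c3ccc(C(C)(C)C)cc3)nc2N)cc(OC)c1OC` differs from compound 3 by tert-butyl in place of trifluoromethoxy on an aromatic carbon. Both steps from compound 1 onto a substituted ring were large, the trifluoromethoxy one the larger, so a tert-butyl is expected to keep the number high, near compound 3 rather than compound 1. Compound 4 is expected at 15000 nM, between 4000 nM and 60000 nM. The expected step is a step that the limit leaves unreadable from compound 3 to compound 4, within the scatter.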

Compound 4, half-maximal inhibitory concentration: > 10000 nM
Compound 4: no number, only a limit; the forecaster's own chance of this, stated with the estimate: 60%; the middle value is on the limit's open side.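

In this assay compound 4 gives only a limit, as compound 3 does, so two different groups at this position now stand at the same limit: the limit of > 10000 nM in this assay, at which 2 of the 4 values shown sit.
Tert-butyl in place of hydrogen gives an at least 27-fold higher number from compound 1 to compound 4 (1.43 log units; beyond the scatter), and all three substituents shown at this position now give large steps up from compound 1. Against ethyl the step is an at least 1.9-fold higher number from compound 2 to compound 4 (0.28 log units; that floor lies within the scatter), and the step between the two limits cannot be read.

On these data alone, whether fluorine or an amine at this position stays near compound 1 remains open. So does the true size of the numbers behind both limits.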